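From 1H-pyrazol-1-yl to tert-butyl: a clearance question

The source may report more compounds than this note shows. Statements on the series, on what has been measured and on what is new or still open speak of the compounds shown alone.

In an ADME assay on liver for metabolic stability, with Liver microsome (Homo sapiens) as the target, read by LC-MS, using microsomes (a lower number here means slower removal, a higher number faster removal of the compound), compound 1 (`O=C(NCc1cc(Cl)ccc1-n1cnnn1)[C@@H]1C[C@@H]2C[C@@H]2N1C(=O)[C@H](O)Cn1cccn1`) gives < 12 mL.min-1.g-1, which is a limit of the assay and not a number. Within the data shown here, compound 2 (`O=C(NCc1cc(Cl)ccc1-n1cnnn1)[C@@H]1C[C@H]2C[C@H]2N1C(=O)[C@H](O)CC1CC1`) gives a true number in this assay, 25 mL.min-1.g-1, but no measured step links it to compound 1.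

Compound 3 (`CC(C)(C)C[C@@H](O)C(=O)N1[C@H](C(=O)NCc2cc(Cl)ccc2-n2cnnn2)C[C@@H]2C[C@@H]21`) departs from compound 1 at one place, with tert-butyl in place of 1H-pyrazol-1-yl on a saturated chain carbon, two bonds along the chain from a carbonyl carbon and an oxygen on a saturated carbon. Among the measured compounds shown here, the only numerical guide to its size is compound 2 at 25 mL.min-1.g-1, so the expectation remains loose. The expected change in this assay is a rise beyond the scatter, an at least 2.5-fold higher number from compound 1 to compound 3 (0.39 log units; beyond the scatter). For compound 3 the estimate is 30 mL.min-1.g-1, with an expected range of 14 mL.min-1.g-1 to 65 mL.min-1.g-1.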

Compound 3, intrinsic clearance in microsomes: 40 mL.min-1.g-1
Compound 3: the middle estimate sits 1.3-fold (0.12 log units) below what was measured, within the range that was stated.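

At this saturated chain carbon, tert-butyl in place of 1H-pyrazol-1-yl gives an at least 3.3-fold higher number from compound 1 to compound 3 (0.52 log units; beyond the scatter) in this assay. Among these compounds, compound 1 and compound 2 alone offered no such step, so this pair is the first to show that the group at this place, with the rest of the structure held the same, goes with a change beyond the scatter. Compound 1 stands at a limit of the assay and not a number, so the step fixes only a lower bound on the change: the limit of < 12 mL.min-1.g-1 in this assay, at which 1 of the 3 values shown sits.

This single pair cannot separate the loss of the aromatic ring and its hydrogen-bond acceptors from the arrival of the purely carbon tert-butyl. Nor does it tell where a morpholine or an amide at this place would fall in this assay.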